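Ester for isopropyl across two inactive core pairs

The compounds below may be only part of what the source reports. "The series", "measured", "known", "first", "only" and "open" are said of these compounds alone.

Compound 1 `CC(C)Cn1nnc(Cc2ccc(-c3ccccc3)cc2)n1` carries an isobutyl group on the aromatic nitrogen of its core. In an assay on isolated protein (COS cells) for inhibition of diacylglycerol lipase-alpha (Homo sapiens) (a higher number here means a weaker inhibitor, a lower number a stronger inhibitor), compound 1 gives > 10000 nM, which is a limit of the assay and not a number. Compound 2 `COC(=O)Cn1nnc(Cc2ccc(-c3ccccc3)cc2)n1` differs from it by methoxycarbonyl in place of isopropyl on a saturated chain carbon bound to an aromatic nitrogen. In this assay compound 2 gives > 10000 nM, again a limit. The step that the two limits leave unreadable from compound 1 to compound 2 is therefore unreadable in both direction and size. Compound 3 `CC(C)Cn1nnc(CNC(=O)c2ccc(-c3ccccc3)cc2)n1` keeps the isobutyl group of compound 1 on a different core; the difference between the two cores is not broken down here. In this assay compound 3 gives > 10000 nM, once more a limit. Across the three, the limit of > 10000 nM in this assay, at which 3 of the 3 values shown sit, is all the information available: no compound gives a number.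

Compound 4 `COC(=O)Cn1nnc(CNC(=O)c2ccc(-c3ccccc3)cc2)n1` has not been measured. It differs from compound 3 by methoxycarbonyl in place of isopropyl on a saturated chain carbon bound to an aromatic nitrogen, the same change as that from compound 1 to compound 2, made at the same kind of place on a saturated chain carbon bound to an aromatic nitrogen. Since compound 1, compound 2 and compound 3 all sit at the limit, nothing measured suggests that either core or either substituent yields a readable number. The expected step that the limit leaves unreadable from compound 3 to compound 4 is accordingly set as no change in this assay. Compound 4 is estimated at 20000 nM, within a range from 8000 nM to 60000 nM, with the greatest likelihood that this assay again reports only a limit.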

Compound 4, half-maximal inhibitory concentration: > 10000 nM
Compound 4 ended at the assay's limit; the forecaster's own chance of this, stated with the estimate: 90%; the middle value lies beyond the limit too.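

For compound 4, > 10000 nM in this assay is a limit of the assay and not a number. Compound 3 also stands at a limit, so no new step can be read from compound 3 and compound 4. Left open is whether either core with either substituent gives a readable number in this assay at all, since every result so far is a limit: the limit of > 10000 nM in this assay, at which 4 of the 4 values shown sit.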